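The source may report more compounds than this note shows. Statements on the series, on what has been measured and on what is new or still open speak of the compounds shown alone.

Three compounds have been measured in a functional assay on HCT-116 cells (Homo sapiens) for cytotoxicity, read by MTT assay; on this read-out lower numbers stand for stronger inhibition and higher numbers for weaker inhibition:

compound 1, `NS(=O)(=O)c1nnc(NCc2nc3cc([N+](=O)[O-])ccc3[nH]2)s1`, with 176000 nM;
compound 2, `CC1=NN(Cc2nc3ccccc3[nH]2)C(=O)C1`, with 42000 nM;
compound 3, `NS(=O)(=O)c1nnc(NCc2nc3ccccc3[nH]2)s1`, with 156000 nM.

Compound 2 gives the lowest number of the three, and its gap to compound 3, like its gap to compound 1, lies beyond the scatter. How the core of compound 2 and the core of compound 3 differ is not broken down here. Compound 3 and compound 1 share a core and differ by one change, (nitro in place of hydrogen on an aromatic carbon); in this assay that change made a 1.1-fold higher number from compound 3 to compound 1 (0.05 log units; within the scatter). Compound 4, `CC1=NN(Cc2nc3cc([N+](=O)[O-])ccc3[nH]2)C(=O)C1`, is not yet measured. Among the measured compounds shown here, it differs from compound 2 by nitro in place of hydrogen on an aromatic carbon, the same change that separates compound 1 from compound 3, and it is the only further instance of this change among the compounds here. Because a 1.1-fold higher number from compound 3 to compound 1 (0.05 log units; within the scatter), compound 4 is expected to stay close to compound 2, with a step of about a 1.1-fold higher number from compound 2 to compound 4 (0.04 log units; within the scatter). That expectation rests on a single earlier step, made on a different core, so the range is kept wide. The estimate for compound 4 is 46000 nM, within a range from 20000 nM to 110000 nM.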

Compound 4, half-maximal inhibitory concentration: 200000 nM
Compound 4: middle estimate off by 4.3-fold (0.64 log units), on the low side; the measured number lies above the stated range.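

In this assay, nitro in place of hydrogen on an aromatic carbon gave a 4.8-fold higher number from compound 2 to compound 4 (0.68 log units; beyond the scatter), so on this core the change made a difference that the scatter does not cover, and the two cores did not respond to it alike: the same change on two cores in this assay, a 1.1-fold higher number (0.05 log units; within the scatter) from compound 3 to compound 1 and a 4.8-fold higher number (0.68 log units; beyond the scatter) from compound 2 to compound 4, 4.2-fold (0.63 log units) apart, beyond the scatter of two such steps. The size of the step did not carry over from the core of compound 3 to the core of compound 2, so in this series a step read on one core was a poor guide to the same change on the other. Among the compounds shown here, with only two pairs, this does not show why the cores part, nor whether any rule ties the size of the step to the core.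

The compounds shown leave open whether an amine or a chloro group in the same place would follow the nitro step on either core. They also leave open whether a third core would side with the small step or with the large one.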